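Series notes: amino acid tail on the shared core

A few compounds are considered here, and "the series" means these few. Any claim that something is new, unique, unknown or untested is made for them only; others in the source may bear on it.

Measured compounds in a functional assay on the whole organism (Tail, strain ICR) with Mus musculus as the target, in the tail flick test, with a stated time of 120 min, at a dose of 25 umol/kg by the oral route; on this read-out higher numbers stand for a stronger effect at the one dose given and lower numbers for a weaker effect:
compound 1 `O=C(CN(c1nc(Cl)nc2[nH]cnc12)C1CC1)N[C@@H](CO)C(=O)OCc1ccccc1` gives 34.5%
compound 2 `O=C(CN(c1nc(Cl)nc2[nH]cnc12)C1CC1)NCC(=O)OCc1ccccc1` gives 21.7%
compound 3 `O=C(CN(c1nc(Cl)nc2[nH]cnc12)C1CC1)N[C@@H](CO)C(=O)O` gives 39%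

Compound 3 has the highest number of the three in this assay; compound 1 sits nearest, and that gap is within the scatter, so no order between the two can be read. Compound 2 sits furthest, and that gap is beyond the scatter. The step of a number 4.5 percentage points higher from compound 1 to compound 3 (within the scatter) is within the scatter, whereas the step of a number 12.8 percentage points lower from compound 1 to compound 2 (beyond the scatter) is a modest loss beyond it.

Compound 4 `CC(C)[C@H](NC(=O)CN(c1nc(Cl)nc2[nH]cnc12)C1CC1)C(=O)O` is not yet measured. It differs from compound 3 by isopropyl in place of hydroxymethyl on a saturated chain carbon bound to an amide-type nitrogen and a carbonyl carbon. The step of a number 12.8 percentage points lower from compound 1 to compound 2 (beyond the scatter) is the one that bears on this: it shows that removing hydroxymethyl at this place lowered the number. Here isopropyl enters rather than hydrogen, so the effect need not match, and no measured pair shows isopropyl at this place. A modest drop, possibly within the scatter, is the expectation, a number 8 percentage points lower from compound 3 to compound 4 (within the scatter). Compound 4 is therefore estimated at 31% in this assay, with a range from 19% to 44%.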

Compound 4, a percentage reported as activity, at one dose (the size of the read-out at that dose, not a potency): 17.1%
The estimate for compound 4 lay 13.9 percentage points above the measured number, and the stated range ends above it.
By their numbers in this assay, from the lowest: compounds 4 and 2 (each within the scatter of the next); then compounds 1 and 3 (each within the scatter of the next).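

In this assay, isopropyl in place of hydroxymethyl on a saturated chain carbon bound to an amide-type nitrogen and a carbonyl carbon gives a number 21.9 percentage points lower from compound 3 to compound 4 (beyond the scatter) with the carboxylic acid present. The loss on removing hydroxymethyl is therefore no longer tied to hydrogen as the replacement or to the benzyl ester: the earlier step, a number 12.8 percentage points lower from compound 1 to compound 2 (beyond the scatter), came with both, and neither is present here. Nothing measured explains either loss.

Still open, from the compounds shown here alone, is how hydrogen at this place behaves with the carboxylic acid, and whether isopropyl gives a similar step with the benzyl ester. Also open, going by these compounds, is how an amine or a longer chain ending in hydroxyl would read at this place.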